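Sulfamoyl chain linkers on a shared oxadiazole-derived core

The source may report more compounds than this note shows. Statements on the series, on what has been measured and on what is new or still open speak of the compounds shown alone.

Compound 1 `NS(=O)(=O)NNc1nonc1/C(=N/O)Nc1ccc(F)c(Br)c1`: 101 nM
Compound 2 `NS(=O)(=O)CCNc1nonc1/C(=N/O)Nc1ccc(F)c(Br)c1`: 11 nM
Compound 3 `CN(C)S(=O)(=O)CCCNc1nonc1/C(=N/O)Nc1ccc(F)c(Br)c1`: 20 nM

In an assay on HeLa cells for inhibition of Indoleamine 2,3-dioxygenase 1 (Homo sapiens), read by spectrophotometry, with a stated time of 24 h (on this read-out lower numbers stand for an effect already at smaller amounts and higher numbers for an effect only at larger amounts of compound), compound 3 gives 20 nM. On the numbers shown it stands second highest of three: its nearest neighbour is compound 2, and the pair lies within the scatter, while the gap to compound 1 is beyond it, as a 5.1-fold lower number from compound 1 to compound 3 (0.70 log units; beyond the scatter) and a 1.8-fold higher number from compound 2 to compound 3 (0.26 log units; within the scatter) record.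

Compound 4 `NS(=O)(=O)CCONc1nonc1/C(=N/O)Nc1ccc(F)c(Br)c1` has not yet been measured. It differs from compound 3 in one place: 2-sulfamoylethoxy in place of 3-(dimethylsulfamoyl)propyl on a nitrogen on an aromatic ring. Among the compounds with values here, two measured steps bear on this. The step of a 9.2-fold lower number from compound 1 to compound 2 (0.96 log units; beyond the scatter) shows that replacing a chain that joins the aromatic nitrogen through a second heteroatom with an all-carbon chain carrying a sulfamoyl group lowered the number strongly. The step of a 1.8-fold higher number from compound 2 to compound 3 (0.26 log units; within the scatter), which alters only the chain length and the substitution of the sulfamoyl group, stayed within the scatter. Compound 4 reintroduces a heteroatom directly on the aromatic nitrogen, so the account places it between compound 2 and compound 1 in the first assay, nearer compound 2. The estimated step is a 1.5-fold higher number from compound 3 to compound 4 (0.18 log units; within the scatter). Compound 4 is therefore expected to give about 30 nM, within a range from 9 nM to 110 nM.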

Compound 4, half-maximal effective concentration: 27 nM
The estimate for compound 4 lay 1.1-fold (0.05 log units) above the measured number, and the stated range covers the measured number.
By their numbers in this assay, from the lowest: compounds 2, 3 and 4 (each within the scatter of the next, the first and the last beyond it); then compound 1.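

In this assay, the 2-sulfamoylethoxy group gives a direct comparison of a chain joined through oxygen with the all-carbon 2-sulfamoylethyl on the same aromatic nitrogen, and the oxygen-joined chain carries a modest cost beyond the scatter (a 2.5-fold higher number from compound 2 to compound 4 (0.39 log units; beyond the scatter)). Against sulfamoylamino, the same group still stands apart (a 3.7-fold lower number from compound 1 to compound 4 (0.57 log units; beyond the scatter)), so a heteroatom on that nitrogen does not by itself return the number to that of compound 1, and the identity of the chain matters as well as the presence of a second heteroatom. Against 3-(dimethylsulfamoyl)propyl, no separation can be claimed (a 1.4-fold higher number from compound 3 to compound 4 (0.13 log units; within the scatter)), although that change alters the chain and the substitution on the sulfamoyl group together, so the two alterations cannot be read apart here.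

No measurement shown here accounts for any of these differences. From the compounds shown here alone, it stays open how a carboxylic acid or an amine would fare in place of the sulfamoyl group at the end of the chain, and whether a longer chain joined through oxygen would follow the all-carbon compounds.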